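The compounds below may be only part of what the source reports. "The series", "measured", "known", "first", "only" and "open" are said of these compounds alone.

Measured so far:
Compound 1 `COc1ccc(-c2nc3cc(/C=C4\SC(=O)N(CC(=O)N5CCOCC5)C4=O)ccc3[nH]2)cc1OC` in a functional assay on HeLa cells (Homo sapiens) for inhibition, read by MTT assay, with a stated time of 48 h (on this read-out lower numbers stand for stronger inhibition and higher numbers for weaker inhibition), gives 7510 nM.
Compound 2 `COc1cc(-c2nc3cc(/C=C4\SC(=O)N(Cc5cccc(C)c5)C4=O)ccc3[nH]2)cc(OC)c1OC` in this assay gives 1440 nM.
Compound 3 `COc1cc(CN2C(=O)S/C(=C\c3ccc4[nH]c(-c5cc(OC)c(OC)c(OC)c5)nc4c3)C2=O)cc(OC)c1OC` in this assay gives 2240 nM.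

Compound 3 holds the second highest of these three numbers; compound 2 is nearest, compound 1 furthest. Compound 4 `COc1ccc(-c2nc3cc(/C=C4\SC(=O)N(Cc5cc(OC)c(OC)c(OC)c5)C4=O)ccc3[nH]2)cc1OC` differs from compound 3 by hydrogen in place of methoxy on an aromatic carbon. Going by the values given here, the only measured step that touches this benzyl group, a 1.6-fold higher number from compound 2 to compound 3 (0.19 log units; within the scatter), swapped the whole ring and stayed within the scatter; no measured step removes a single methoxy from it, so no direction can be drawn. Compound 4 is therefore expected near compound 3, and the step of a 1.1-fold higher number from compound 3 to compound 4 (0.05 log units; within the scatter) is estimated to be within the scatter. The estimate for compound 4 in this assay is 2500 nM, with a range from 1000 nM to 6500 nM.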

Compound 4, half-maximal inhibitory concentration: 320 nM
Estimate against measurement, compound 4: 7.8-fold (0.89 log units) above, outside the stated range (below it).
By their numbers in this assay, from the lowest: compound 4; then compounds 2 and 3 (each within the scatter of the next); then compound 1.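

In this assay, losing one methoxy, 3,4,5-trimethoxyphenyl to 3,4-dimethoxyphenyl on the aryl ring of the shared core, gives a 7.0-fold lower number from compound 3 to compound 4 (0.85 log units; beyond the scatter), so a single methoxy at this place moves the number beyond the scatter. With that 3,4-dimethoxyphenyl kept, 3,4,5-trimethoxyphenyl in place of (morpholin-4-yl)carbonyl on the other side of the molecule gives a 23-fold lower number from compound 1 to compound 4 (1.37 log units; beyond the scatter). Nothing available explains either step. On these data alone, whether a hydroxyl or a chlorine at this place would keep the lower number stays open, as does whether removing one methoxy from the other 3,4,5-trimethoxyphenyl would have a similar result.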